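The source may hold more compounds than are shown below. What is called first, only, known or untested is meant among the compounds shown, and "the series" means these compounds.

Of the compounds shown here, two have been read in an assay on isolated protein for inhibition of interferon-induced, double-stranded RNA-activated protein kinase (Homo sapiens), read by luminescence, with a stated time of 10 min; on this read-out lower numbers stand for stronger inhibition and higher numbers for weaker inhibition. Compound 1 `C=C1NNC(=O)N=C1Nc1ccc2cn[nH]c2c1` gives 16000 nM there. Compound 2 `c1ccc(-c2[nH]c3ccccc3c2-c2ccnc(NC3CCCC3)n2)cc1` gives only a limit of this assay, > 100000 nM, and nothing more exact is known of it. Compound 3 `Fc1ccc(Nc2nccc(-c3c(-c4ccccc4)[nH]c4ccccc34)n2)cc1` differs from compound 2 by 4-fluorophenyl in place of cyclopentyl on a nitrogen on an aromatic ring. Among the compounds with values here, no measured pair carries this change, so no size for the step can be taken from the series; the expectation is a shift no larger than the usual scatter, with some chance of a modest gain. Compound 3 is estimated at 60000 nM, within 10000 nM to 200000 nM. The expected step from compound 2 to compound 3 is an at least 1.6-fold lower number from compound 2 to compound 3 (0.22 log units; that floor lies within the scatter).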

Compound 3, half-maximal inhibitory concentration: 7000 nM
Estimate against measurement, compound 3: 8.6-fold (0.93 log units) above; the whole stated range lies above it.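

The position on a nitrogen on an aromatic ring responds strongly to the group it carries: 4-fluorophenyl in place of cyclopentyl gives an at least 14-fold lower number from compound 2 to compound 3 (1.15 log units; beyond the scatter) in this assay. Within the data shown here, this is the only step so far, and it lies beyond the scatter. Compound 2 sits at a limit of the assay, so the step gives a floor and not a full size: the limit of > 100000 nM in this assay, at which 1 of the 3 values shown sits.

Going by these compounds, whether the step belongs to the fluorine or to the phenyl ring itself stays open, and plain phenyl on the same nitrogen would separate the two. Also open, on these data alone, is how a carboxylic acid or a morpholine on that ring would read.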